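A few compounds are considered here, and "the series" means these few. Any claim that something is new, unique, unknown or untested is made for them only; others in the source may bear on it.

For the measured compounds named here, compound 3 `Cc1c(OCCCCOc2ccc(C(=O)O)c(Cl)c2)ccc(C(=O)CC(C)C)c1C` gives 12% in an assay on HEK293 cells for positive allosteric modulation of metabotropic glutamate receptor 3 (Rattus norvegicus), read by thallium flux, with a stated time of 2.5 min (on this read-out higher numbers stand for larger maximal responses and lower numbers for smaller maximal responses), the lowest of the three numbers measured so far. Compound 2 `Cc1c(OCCCCOc2cccc(C(=O)O)c2)ccc(C(=O)CC(C)C)c1C` gives 18.3%, and the step of a number 6.3 percentage points lower from compound 2 to compound 3 (within the scatter) stays within the scatter of the assay. Compound 1 `COC(=O)c1ccc(OCCCCOc2ccc(C(=O)CC3CCCC3)c(C)c2C)cc1` gives 24.2%, a number that stands beyond the scatter above compound 3.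

Compound 4 `COC(=O)c1ccc(OCCCCOc2ccc(C(=O)CC(C)C)c(C)c2C)cc1` has not yet been measured. It differs from compound 3 by 4-(methoxycarbonyl)phenyl in place of 4-carboxy-3-chlorophenyl on an oxygen on a saturated carbon. Going by the values given here, no measured step shows this exchange directly; the only single-place step available is the one from compound 2 to compound 3, and that one was within the scatter. Compound 1 carries the same 4-(methoxycarbonyl)phenyl group as compound 4 and differs from it only elsewhere in the molecule, so the value of compound 1 is the closest guide. Compound 4 is therefore expected to reach about 22%, with a likely range from 10% to 34%. This estimate implies an expected step of a number 10 percentage points higher from compound 3 to compound 4 (within the scatter), an increase that may just reach beyond the scatter.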

Compound 4, largest response reached (reported as percent of maximum), in percent of the reference or control that the assay uses: 27.3%
The estimate for compound 4 lay 5.3 percentage points below the measured number; the measured number falls inside the stated range.
By their numbers in this assay, from the lowest: compounds 3, 2, 1 and 4 (each within the scatter of the next, the first and the last beyond it).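

For the compounds shown here, the exchange of 4-carboxy-3-chlorophenyl for 4-(methoxycarbonyl)phenyl on the oxygen gives a number 15.3 percentage points higher from compound 3 to compound 4 (beyond the scatter) in this assay, the first step at this place that is printed beyond the scatter. The same entering group in place of 3-carboxyphenyl gives a number 9 percentage points higher from compound 2 to compound 4 (within the scatter), so only one of the two carboxy-bearing groups stands apart from it. Elsewhere in the molecule, isopropyl in place of cyclopentyl on a saturated chain carbon bound to a carbonyl carbon gives a number 3.1 percentage points higher from compound 1 to compound 4 (within the scatter), so the two groups cannot be told apart on this read-out. Nothing available explains these differences.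

The step from compound 3 exchanges the carboxylic acid, the chlorine and the substitution pattern at once, and the compounds shown do not separate these. On these data alone, what a plain 4-carboxyphenyl or a 4-cyanophenyl group would give on this oxygen remains open.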